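The source may report more compounds than this note shows. Statements on the series, on what has been measured and on what is new or still open speak of the compounds shown alone.

Compound 1 `Nc1sc(Br)c(-c2cccc(C(F)(F)F)c2)c1C(=O)c1ccccc1`: > 10 uM
Compound 2 `CCOC(=O)c1c(-c2cccc(C(F)(F)F)c2)csc1N`: 9.4 uM
Compound 3 `CC(=O)c1cccc(-c2sc(N)c(C(=O)c3ccccc3)c2-c2cccc(C(F)(F)F)c2)c1`: > 10 uM

In a functional assay on CHO-K1 cells for agonist activity at adenosine receptor A1 (Homo sapiens), read by GTPgammaS binding (a lower number here means that less compound is needed, a higher number that more compound is needed for the effect), compound 2 gives 9.4 uM, the only plain number among the three results shown. The result for compound 1 is a limit of the assay. The result for compound 3 is likewise a limit. Compound 4 `CCOC(=O)c1c(N)sc(-c2ccc(C(C)=O)cc2)c1-c1cccc(C(F)(F)F)c1` differs from compound 2 by 4-acetylphenyl in place of hydrogen on an aromatic carbon. Going by the values given here, the one measured step of related kind, a step that the two limits leave unreadable from compound 1 to compound 3, has no readable size because of the limit of > 10 uM in this assay, at which 2 of the 3 values shown sit, so no measured step fixes how large the change from compound 2 to compound 4 should be. Compound 4 is expected to sit near or somewhat past compound 2, the step of a 1.6-fold higher number from compound 2 to compound 4 (0.20 log units; within the scatter) being an estimate only. The estimate for compound 4 is 15 uM, within a range from 5 uM to 50 uM.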

Compound 4, concentration for half-maximal effect: > 10 uM
Compound 4: no number, only a limit; the forecaster's own chance of this, stated with the estimate: 50%; the middle value lies beyond the limit too.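

Placing 4-acetylphenyl on the aromatic carbon next to the ring sulfur gives an at least 1.0-fold higher number from compound 2 to compound 4 (0.02 log units; that floor lies within the scatter), the first step at this position that starts from a plain number. The added ring therefore brings no readable gain in this assay, but the true size of the step stays hidden because of a shared limit: the limit of > 10 uM in this assay, at which 3 of the 4 values shown sit.

As far as these compounds go, how far past this limit compound 4 lies remains open. So does whether a smaller group at this position, such as a methyl or an amine, or a carboxylic acid in place of the acetyl, would lower the number.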